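From phenyl to 4-methylphenyl: a small change to compound 1

The source may hold more compounds than are shown below. What is called first, only, known or untested is meant among the compounds shown, and "the series" means these compounds.

Among the compounds with values here, in an ADME assay on MDCK cells (Canis lupus familiaris) for cytotoxicity (a lower number here means that less compound is tolerated, a higher number that more compound is tolerated), compound 1 `CCN(CC)CN1C(=O)/C(=N/NC(=S)Nc2ccccc2)c2cc(Cl)ccc21` gives 3000 nM, the lowest of the three numbers measured so far. Compound 2 `CCN(CC)CN1C(=O)/C(=N/NC(N)=S)c2cc(Cl)ccc21`, with hydrogen in place of the phenyl, gives 78300 nM. Compound 3 `CCN(CC)CN1C(=O)/C(=N/NC(=S)Nc2ccc(OC)cc2)c2cc(Cl)ccc21`, with 4-methoxyphenyl in place of the phenyl, gives 11100 nM.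

Compound 4 `CCN(CC)CN1C(=O)/C(=N/NC(=S)Nc2ccc(C)cc2)c2cc(Cl)ccc21` has not yet been measured. It differs from compound 1 by one small edit: methyl in place of hydrogen on an aromatic carbon. That is, methyl in place of hydrogen on an aromatic carbon, turning phenyl into 4-methylphenyl.

The closest guide is the modest step of a 3.7-fold higher number from compound 1 to compound 3 (0.57 log units; beyond the scatter), which also adds a substituent to the phenyl and gives a 4-substituted phenyl. The large step of a 26-fold higher number from compound 1 to compound 2 (1.42 log units; beyond the scatter) removes the whole phenyl, so it says less about so small an edit. The modest step of a 7.1-fold lower number from compound 2 to compound 3 (0.85 log units; beyond the scatter) shows that compound 3 still lies well under compound 2 in this assay.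

Within the data shown here, with only one close comparison, the direction is tentative, but a small rise seems likely. The expected step is a 2.0-fold higher number from compound 1 to compound 4 (0.30 log units; within the scatter), which may not clear the usual scatter. For compound 4 the estimated value is 6000 nM, with an expected range from 2500 nM to 14000 nM.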

Compound 4, half-maximal cytotoxic concentration: 11300 nM
For compound 4 the middle estimate is 1.9-fold (0.27 log units) below the measured one; the range from low to high includes it.
By their numbers in this assay, from the lowest: compound 1; then compounds 3 and 4 (each within the scatter of the next); then compound 2.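

In this assay, a single methyl on the phenyl ring, para to a large group, gives a 3.8-fold higher number from compound 1 to compound 4 (0.58 log units; beyond the scatter), so the rise seen earlier with methoxy is no longer a lone case. Methyl and methoxy cannot be told apart at this position, with a 1.0-fold higher number from compound 3 to compound 4 (0.01 log units; within the scatter), so the oxygen atom of methoxy makes no visible difference between these two compounds. The step of a 6.9-fold lower number from compound 2 to compound 4 (0.84 log units; beyond the scatter) shows that, even with the methyl, the 4-methylphenyl group leaves the number well short of what hydrogen on that nitrogen allows, and no measurement at hand explains why either change moves the number as it does.

The compounds shown carry only methyl or methoxy at this position, so it stays open whether a halogen such as chlorine, an amine or a carboxylic acid there would give a similar number. On these data alone, it is also open whether a longer chain, such as butyl, would stay level with these two compounds or come closer to compound 2 at 78300 nM.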